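Solubility of a lactam core: swapping the amide substituent

The compounds below may be only part of what the source reports. "The series", "measured", "known", "first", "only" and "open" are said of these compounds alone.

Compound 1, `CC(C)C[C@@H]1C(=O)N[C@H](C2Cc3ccccc3C2)C(=O)N1[C@@H](C(=O)NC(C)C)c1ccc(Br)s1`: < 1 ug/mL
Compound 2, `Cc1nc([C@H](C(=O)NC(C)C)N2C(=O)[C@@H](C3Cc4ccccc4C3)NC(=O)[C@H]2CC(C)C)co1`: > 240 ug/mL

Of the compounds shown here, two of this core have been measured in a physicochemical assay for solubility; on this read-out higher numbers stand for higher solubility and lower numbers for lower solubility. Compound 1 sits at a limit of this assay, < 1 ug/mL, as shown by the limit of < 1 ug/mL in this assay, at which 1 of the 2 values shown sits. Compound 2 also sits at a limit, > 240 ug/mL, as shown by the limit of > 240 ug/mL in this assay, at which 1 of the 2 values shown sits. Going by the values given here, the step between them, an at least 240-fold higher number from compound 1 to compound 2 (2.38 log units; beyond the scatter), is the only measured step, and it concerns the group on the saturated chain carbon, not the carbonyl-bound amine that changes now.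

Compound 3, `Cc1nc([C@H](C(=O)N(C)CCO)N2C(=O)[C@@H](C3Cc4ccccc4C3)NC(=O)[C@H]2CC(C)C)co1`, differs from compound 2 as follows: (2-hydroxyethyl)(methyl)amino in place of isopropylamino on a carbonyl carbon. Among the compounds with values here, no measured pair speaks to this change on a carbonyl carbon, so the single measured step bears on it only through the shared core. Compound 2 already sits at the upper limit, and compound 3 is expected to remain there, with the estimated step of a number no higher from compound 2 to compound 3 (the limit leaves the size open) reflecting no change beyond the scatter. Compound 3 is therefore estimated at 240 ug/mL, with a range from 150 ug/mL to 400 ug/mL.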

Compound 3, solubility: > 220 ug/mL
Compound 3 was reported as a limit; the forecaster's own chance of this, stated with the estimate: 70%; the middle value does not contradict the limit.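

In this assay compound 3 gives > 220 ug/mL, which is a limit, and compound 2 is likewise reported only as a limit, so no step can be read between compound 2 and compound 3. The compounds shown leave open whether (2-hydroxyethyl)(methyl)amino in place of isopropylamino on a carbonyl carbon changes the number in this assay at all, and in which direction.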